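From (vinylcarbonyl)amino to fluoro: an expected half-life

A few compounds are considered here, and "the series" means these few. Any claim that something is new, unique, unknown or untested is made for them only; others in the source may bear on it.

Compound 1 `C=CC(=O)Nc1cc(C(F)(F)F)cc(C(F)(F)F)c1`: 5.5 h
Compound 2 `C=CS(=O)(=O)c1cc(C(F)(F)F)cc(C(F)(F)F)c1`: < 0.017 h
Compound 3 `O=C1C=CC(=O)N1c1cc(C(F)(F)F)cc(C(F)(F)F)c1`: < 0.017 h

Among the compounds with values here, in an ADME assay for pharmacokinetics, read by LC-MS, in phosphate buffer, with a stated time of 72 h, at pH 7.4, tested at 250 uM (on this read-out higher numbers stand for a longer-lived compound and lower numbers for a shorter-lived compound), compound 1 gives 5.5 h, the only actual number among the three measured compounds. Compound 2 is reported only as a limit of the assay, < 0.017 h. Compound 3 is likewise reported as a limit, < 0.017 h. the limit of < 0.017 h in this assay, at which 2 of the 3 values shown sit, is the floor at which those two values rest. Measured from compound 1, the two steps are an at least 320-fold lower number from compound 1 to compound 2 (2.50 log units; beyond the scatter) and an at least 320-fold lower number from compound 1 to compound 3 (2.50 log units; beyond the scatter); between the two compounds at the floor, a step that the two limits leave unreadable from compound 2 to compound 3.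

Compound 4 `Fc1cc(C(F)(F)F)cc(C(F)(F)F)c1` has not yet been measured. Its difference from compound 1 is fluoro in place of (vinylcarbonyl)amino on an aromatic carbon. Both measured steps alter this same position on the shared core, and both exchange the (vinylcarbonyl)amino for another group and fall to the floor. Neither of them puts a fluoro in its place, so they give no direct reading of the present step. What they show is that this position controls the read-out strongly, and that compound 1 already holds the longest measured value.

Compound 4 is expected to be longer-lived than compound 1, with a step of a 27-fold higher number from compound 1 to compound 4 (1.44 log units; beyond the scatter). The estimate for compound 4 is 150 h, within a range of 40 h to 1000 h, and such a number may well lie past the window of the assay, so that only a limit is reported.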

Compound 4, half-life: > 50 h
Compound 4: no number, only a limit (the forecaster's own chance of this, stated with the estimate: 70%); the middle value lies beyond the limit too.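

Until now every exchange at this position had pushed the half-life down, leaving open whether the (vinylcarbonyl)amino of compound 1 was already the best group shown; fluoro moves the read-out the other way, with an at least 9.0-fold higher number from compound 1 to compound 4 (0.95 log units; beyond the scatter). Against the two compounds at the floor the span is far wider, with an at least 2900-fold higher number from compound 3 to compound 4 (3.46 log units; beyond the scatter) and with an at least 2900-fold higher number from compound 2 to compound 4 (3.46 log units; beyond the scatter), so this one position carries the values of this assay from one limit to the other. Compound 4 is reported only as a limit and not as a number, so the full size of its gain stays unread: the limit of > 50 h in this assay, at which 1 of the 4 values shown sits.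

Fluoro is the only group shown with no double bond outside the aromatic ring, yet compound 1 keeps such bonds and still stays clear of the floor, so the data do not tie the short half-lives to those bonds alone. The data do not show whether groups other than fluoro in place of the (vinylcarbonyl)amino would also give a long half-life. A saturated propanoylamino group, a plain amine or a bare hydrogen at the same position would show this.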